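The compounds below may be only part of what the source reports. "The series", "measured", "known", "first", "only" and "open" are said of these compounds alone.

Measured compounds in a functional assay on SR cells (Homo sapiens) for inhibition, read by sulforhodamine B assay, with a stated time of 48 h; on this read-out lower numbers stand for stronger inhibition of growth and higher numbers for weaker inhibition of growth:
compound 1, `COc1ccc(-c2cc(/C=C/C(=O)c3ccc(N)cc3)[nH]n2)cc1`: 6090 nM
compound 2, `COc1ccc(C(=O)/C=C/c2cc(-c3cc(OC)c(OC)c(OC)c3)n[nH]2)cc1OC`: > 100000 nM, a limit of the assay rather than a number
compound 3, `COc1ccc(C(=O)/C=C/c2cc(-c3cc(OC)c(OC)c(OC)c3)n[nH]2)cc1`: 23900 nM

Of the two numbers in hand, compound 1 has the lowest, and compound 3 stands nearest with a higher number beyond the scatter. Compound 2 reached only (the limit of > 100000 nM in this assay, at which 1 of the 3 values shown sits), so no number is known for it. Within the data shown here, the one measured step joins compound 2 to compound 3, an at least 4.1-fold lower number from compound 2 to compound 3 (0.62 log units; beyond the scatter): it amounts to hydrogen in place of methoxy on an aromatic carbon, and taking a methoxy away lowered the number. The new compound 4, `COc1ccc(-c2cc(/C=C/C(=O)c3ccc(N)cc3)[nH]n2)cc1OC`, is made from compound 1 by the reverse kind of change, (methoxy in place of hydrogen on an aromatic carbon), though on a different ring of the shared core. Among the measured compounds shown here, only that single step bears on it, and in the reverse direction it points toward a higher number, so the expectation is that adding the methoxy weakens growth inhibition. The expected step is a 3.0-fold higher number from compound 1 to compound 4 (0.47 log units; beyond the scatter), in this assay. Compound 4 is therefore estimated at 18000 nM in this assay, with a plausible range from 6000 nM to 60000 nM.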

Compound 4, concentration for total growth inhibition: 5310 nM
For compound 4 the middle estimate is 3.4-fold (0.53 log units) above the measured one, outside the stated range (below it).
By their numbers in this assay, from the lowest: compounds 4 and 1 (each within the scatter of the next); then compound 3. At a limit, above all of these: compound 2.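

In this assay the added methoxy, ortho to a methoxy group and meta to a large group, leaves growth inhibition where it was: the step is a 1.1-fold lower number from compound 1 to compound 4 (0.06 log units; within the scatter), so the two compounds cannot be told apart. Among these compounds, the only earlier step of this kind rests on compound 2, which gives > 100000 nM, a limit of the assay and not a number. Even so, the result shows that the effect of this change does not carry over from one core to the other, and that an added methoxy need not weaken growth inhibition, as the two steps lie clearly apart: the same change on two cores in this assay, an at least 4.1-fold lower number (0.62 log units; beyond the scatter) from compound 2 to compound 3 and a 1.1-fold higher number (0.06 log units; within the scatter) from compound 4 to compound 1, at least 4.7-fold (0.68 log units) apart, beyond the scatter of two such steps.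

From the compounds shown here alone, whether this position would accept other groups, such as a hydroxyl, a fluorine or an ethoxy, remains open. The compounds shown also cannot tell which of the several differences between the two cores, or the different ring that carries the change, separates the two steps.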